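Working notes: adding benzoyloxy to compound 2

The source may report more compounds than this note shows. Statements on the series, on what has been measured and on what is new or still open speak of the compounds shown alone.

Values in an ADME assay on Vero cells (Chlorocebus sabaeus) for cytotoxicity, read by sulforhodamine B assay, with a stated time of 72 h; a lower number here means a stronger inhibitor, a higher number a weaker inhibitor:
- Compound 1 `CN1CCc2cc(OCc3ccccc3)ccc2C1`: > 100000 nM
- Compound 2 `CN1CCc2cc(OCc3ccc(-c4ccccc4)cc3)ccc2C1`: 16500 nM
- Compound 3 `CN1Cc2ccc(OCc3ccc(-c4ccccc4)cc3)cc2[C@H](OC(=O)c2ccccc2)C1`: not yet measured

Among the compounds with values here, compound 2, at 16500 nM, holds the only actual number in this assay so far. Compound 1 stands at > 100000 nM, which is a limit of the assay and not a number.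

The next change is benzoyloxy in place of hydrogen on a saturated ring carbon. Within the data shown here, one measured step bears on it, an at least 6.0-fold lower number from compound 1 to compound 2 (0.78 log units; beyond the scatter). That step also brought in a six-membered aromatic ring, as a phenyl on an aromatic carbon, and it lies beyond the scatter. On these data alone, it starts from the limit of > 100000 nM in this assay, at which 1 of the 2 values shown sits, so its true size is unknown. Among the measured compounds shown here, it is also only a loose guide, since the new group enters at a saturated ring carbon instead and no measured step covers that kind of site.

A lower number is therefore expected in this assay, but only a modest change. The expected step is a 2.1-fold lower number from compound 2 to compound 3 (0.31 log units; beyond the scatter). For compound 3 the estimate is 8000 nM, with an expected range of 2500 nM to 30000 nM.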

Compound 3, half-maximal inhibitory concentration: 12900 nM
The estimate for compound 3 lay 1.6-fold (0.21 log units) below the measured number; measured number inside the range.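

At the saturated ring carbon two ring bonds from the ring nitrogen, benzoyloxy gives in this assay a 1.3-fold lower number from compound 2 to compound 3 (0.11 log units; within the scatter), so compound 2 and compound 3 cannot be told apart here, even though the new group brings 9 heavy atoms and one six-membered aromatic ring. Within the data shown here, the only earlier step, on an aromatic carbon, also brought in a six-membered aromatic ring and is printed as beyond the scatter: an at least 6.0-fold lower number from compound 1 to compound 2 (0.78 log units; beyond the scatter); the two sites therefore differ in what the measured steps show, though one pair at each site is thin support for any wider rule. Compound 1 holds a limit and not a number, so the earlier step has no exact size: the limit of > 100000 nM in this assay, at which 1 of the 3 values shown sits.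

Open, on these data alone, is whether this saturated ring carbon stays as undemanding in this assay with a free hydroxyl, an amine or a carboxylic acid in place of benzoyloxy, or whether the ester link matters to the reading. The compounds shown also leave open how the opposite configuration at this carbon reads, as compound 3 is the only compound shown with a group there.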